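This account rests on a few compounds, and the source may have more. Where it says the series, first, only, none or still open, it means among the compounds named here.

Measured compounds and their values:

Compound 1, `Cc1nn(C)c2c1C(c1ccccc1)=NCCN2`, 2.5 mg/kg
Compound 2, `Cc1nn(C)c2c1C(c1cccc(F)c1)=NCCN2`, 2.5 mg/kg

In a functional assay on the whole organism for positive allosteric modulation, with Rattus norvegicus as the target (on this read-out lower numbers stand for an effect already at smaller amounts and higher numbers for an effect only at larger amounts of compound), compound 1 gives 2.5 mg/kg. Compound 2 carries a fluoro in place of hydrogen on an aromatic carbon, and in this assay compound 2 gives 2.5 mg/kg. The step of no change at the digits printed from compound 1 to compound 2 (within the scatter) shows that this substitution left the read-out unchanged within the scatter, so compound 2 stands level with compound 1 on the numbers shown.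

Compound 3, `Cc1nn(C)c2c1C(c1cccc([N+](=O)[O-])c1)=NCCN2`, differs from compound 2 by nitro in place of fluoro on an aromatic carbon. Among the compounds with values here, the only measured step that bears on this change is the one from compound 1 to compound 2, which touched the same aromatic carbon and was flat within the scatter. Within the data shown here, no measured pair shows how a nitro group behaves in this assay, so the account rests on that single flat step. Compound 3 is therefore expected to show a step of no change at the digits printed from compound 2 to compound 3 (within the scatter), that is, no change beyond the scatter. In this assay compound 3 is estimated at 2.5 mg/kg, with a range from 1 mg/kg to 8 mg/kg.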

Compound 3, minimum effective dose: 5 mg/kg
Compound 3: middle estimate off by 2.0-fold (0.30 log units), on the low side, within the range that was stated.
By their numbers in this assay, from the lowest: compounds 1, 2 and 3 (each within the scatter of the next).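

In this assay the aromatic carbon meta to a large group now holds a third kind of substituent: putting nitro in place of fluoro gives a 2.0-fold higher number from compound 2 to compound 3 (0.30 log units; within the scatter) and putting nitro in place of hydrogen gives a 2.0-fold higher number from compound 1 to compound 3 (0.30 log units; within the scatter) at the same carbon. Nitro brings more heavy atoms than fluoro, a double bond outside the aromatic ring and hydrogen-bond acceptors that fluoro lacks, yet neither step leaves the scatter, so hydrogen, fluoro and nitro at this carbon cannot be told apart on this read-out. Nothing in the available data offers an explanation for this result.

The compounds shown leave open whether any group at this carbon moves the minimum effective dose beyond the scatter, for instance an amine, a carboxylic acid or a longer alkyl chain. They also leave open whether fluoro and nitro would read the same at the other carbons of this ring, and whether the core of compound 1 would hold its level with an ethyl group in place of either methyl group.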